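The compounds below may be only part of what the source reports. "The series", "measured", "known", "first", "only" and "open" are said of these compounds alone.

Of the compounds shown here, two built on a shared core have been measured in an assay on isolated protein for binding affinity to 5-hydroxytryptamine receptor 6 (Homo sapiens); a higher number here means a weaker inhibitor, a lower number a stronger inhibitor. Compound 1 `COc1ccccc1-c1cc(CN(C)C)ccc1Cl` gives 440 nM in this assay. Compound 2 `CCNCc1ccc(Cl)c(-c2ccccc2OC)c1` gives 1400 nM in this assay, the highest of the two numbers; its nearest neighbour is compound 1, and the step from compound 1 to compound 2 is a 3.2-fold higher number from compound 1 to compound 2 (0.50 log units; beyond the scatter).

Compound 3 `CCN(CC)Cc1ccc(Cl)c(-c2ccccc2OC)c1` is not yet measured. It differs from compound 2 in one place: ethyl in place of hydrogen on an amine nitrogen. Going by the values given here, the only measured step that bears on this is the one from compound 1 to compound 2, which was a 3.2-fold higher number from compound 1 to compound 2 (0.50 log units; beyond the scatter) and ran from dimethylamino to ethylamino. The present change runs the other way, from ethylamino to diethylamino, so a modest step toward a lower number in this assay is expected, though diethylamino is not dimethylamino and the size is uncertain. Compound 3 is expected to give 800 nM in this assay, within a range from 300 nM to 2500 nM. The expected step is a 1.8-fold lower number from compound 2 to compound 3 (0.24 log units; within the scatter).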

Compound 3, inhibition constant: 2000 nM
Estimate against measurement, compound 3: 2.5-fold (0.40 log units) below; measured number inside the range.
By their numbers in this assay, from the lowest: compound 1; then compounds 2 and 3 (each within the scatter of the next).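

Placing a second ethyl on the amine nitrogen of compound 2 gives a 1.4-fold higher number from compound 2 to compound 3 (0.15 log units; within the scatter), so in this assay this change makes no difference that can be told from ordinary assay variation. The comparison of the two fully substituted amines is clearer: going from dimethylamino to diethylamino gives a 4.5-fold higher number from compound 1 to compound 3 (0.66 log units; beyond the scatter), and among these three compounds, only compound 1, with dimethylamino, stands apart from the other two, which both carry ethyl on the nitrogen. No available evidence explains this difference.

The compounds shown leave open whether methylamino, with a single methyl on the nitrogen, or an unsubstituted amino group would fall closer to compound 1 or to compound 3. As far as these compounds go, how a longer chain such as propyl on the nitrogen would behave also remains open.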